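The compounds below may be only part of what the source reports. "The series", "measured", "known", "first", "only" and "open" are said of these compounds alone.

In a functional assay on H9c2 cells (Mus musculus) for cytotoxicity against H9c2 (Rattus norvegicus), read by MTT assay, with a stated time of 24 h (on this read-out higher numbers stand for an effect only at larger amounts of compound and lower numbers for an effect already at smaller amounts), the measured compounds stand as follows:

compound 1 `COc1ccc(Cc2coc3cc(O)cc(O)c3c2=O)cc1`: > 100000 nM
compound 2 `COc1ccc(Cc2coc3cc(O)cc(O)c3c2=O)cc1OC`: 12100 nM
compound 3 `O=c1c(Cc2ccc(C(F)(F)F)cc2)coc2cc(O)cc(O)c12`: 12700 nM

The value of compound 1 is a limit of this assay and not a number, which is where one of the three compounds sits (the limit of > 100000 nM in this assay, at which 1 of the 3 values shown sits). Compound 1 therefore stands at the edge of what this assay reports, with no measured number of its own.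

Compound 4 `COc1ccc(Cc2coc3cc(O)ccc3c2=O)cc1` differs from compound 1 on the shared core: hydrogen in place of hydroxy on an aromatic carbon, on an aromatic carbon of a six-membered aromatic ring of carbon only, part of a fused or bridged system of two rings, ortho to a fused ring, meta to a fused ring and meta to a hydroxy group.

Neither measured step touches this position. The step of an at least 8.2-fold lower number from compound 1 to compound 2 (0.91 log units; beyond the scatter) and the step of an at least 7.8-fold lower number from compound 1 to compound 3 (0.89 log units; beyond the scatter) both alter the pendant aryl group and leave the two hydroxy groups of the core in place. Among the compounds with values here, they show only that changes elsewhere can move compound 1 off the limit; they say nothing about the loss of a core hydroxy. Within the data shown here, with no step bearing on the change, no step beyond the scatter is expected in this assay, so compound 4 is expected to stay near the limit, a number no higher from compound 1 to compound 4 (the limit leaves the size open).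

Compound 4 is estimated at 100000 nM, within 30000 nM to 300000 nM, most likely reported again as a limit.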

Compound 4, half-maximal effective concentration: 32100 nM
Estimate against measurement, compound 4: 3.1-fold (0.49 log units) above, and the stated range covers the measured number.
By their numbers in this assay, from the lowest: compounds 2 and 3 (each within the scatter of the next); then compound 4. At a limit, above all of these: compound 1.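

In this assay, the loss of a core hydroxy moves the read-out on its own: hydrogen in place of hydroxy on an aromatic carbon, ortho to a fused ring and meta to a hydroxy group, gives an at least 3.1-fold lower number from compound 1 to compound 4 (0.49 log units; beyond the scatter). The earlier steps had shown such movement only for changes on the pendant aryl group, whereas this step leaves that group as it stands in compound 1 and shows that this position on the shared core also counts in this read-out. The full size of the step cannot be read, since the value of compound 1, > 100000 nM, is a limit and not a number: the limit of > 100000 nM in this assay, at which 1 of the 4 values shown sits.

The compounds shown leave open whether hydrogen itself matters here or only the absence of hydroxy, which a fluorine, a methoxy or an amine at this position would help to separate. They also leave open what the remaining core hydroxy contributes, and whether the loss of the hydroxy at this position would combine with the pendant groups of compound 2 and compound 3.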